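Benzamide series: ring swaps on the amine-bound methylene

The source may report more compounds than this note shows. Statements on the series, on what has been measured and on what is new or still open speak of the compounds shown alone.

Compound 1 `COc1cc(N)c(Cl)cc1NC(=O)C1CCN(CC2CCCCC2)CC1`: 2.9 mg/kg
Compound 2 `COc1cc(N)c(Cl)cc1NC(=O)C1CCN(Cc2ccccc2Cl)CC1`: > 4 mg/kg
Compound 3 `COc1cc(N)c(Cl)cc1NC(=O)C1CCN(Cc2ccsc2)CC1`: not yet measured

Among the measured compounds shown here, in a functional assay on the whole organism for antagonist activity, with Mus musculus as the target (a higher number here means that more compound is needed for the effect, a lower number that less compound is needed), compound 1 gives 2.9 mg/kg, the only numeric result so far. For compound 2 this assay returns only a limit, > 4 mg/kg, so no number is known for it. For the measured compounds named here, the one measured step, an at least 1.3-fold higher number from compound 1 to compound 2 (0.13 log units; that floor lies within the scatter), is set by the limit of > 4 mg/kg in this assay, at which 1 of the 2 values shown sits, and therefore gives a floor rather than a size. Compound 3 differs from compound 1 by thiophen-3-yl in place of cyclohexyl on a saturated chain carbon bound to an amine nitrogen in a ring. This resembles the step to compound 2 in that an aromatic ring replaces cyclohexyl, so the same direction is expected: a higher number, quite possibly again ending at a limit. Compound 3 is therefore expected at 4.5 mg/kg with a range of 1.8 mg/kg to 12 mg/kg. The expected step of a 1.6-fold higher number from compound 1 to compound 3 (0.19 log units; within the scatter) would sit near the edge of the usual scatter.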

Compound 3, dose for half-maximal effect: 3.4 mg/kg
Beside the measured number, compound 3's estimate is 1.3-fold (0.12 log units) above it, within the range that was stated.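

In this assay, the swap of cyclohexyl for thiophen-3-yl on the saturated chain carbon bound to the amine nitrogen in a ring gives a 1.2-fold higher number from compound 1 to compound 3 (0.07 log units; within the scatter), so at this place an aromatic ring can return a number that stays within the scatter of the cyclohexyl compound. Compound 2 remains a limit, > 4 mg/kg, not a number. Its comparison with the thiophene gives an at least 1.1-fold lower number from compound 2 to compound 3 (0.07 log units; that floor lies within the scatter), which is a floor only and shows no separation of these two aromatic groups: the limit of > 4 mg/kg in this assay, at which 1 of the 3 values shown sits.

Still open, on these data alone, is whether an unsubstituted phenyl or thiophen-2-yl would stay within the scatter of compound 1. Also open, as far as these compounds go, is whether a longer chain, such as cyclohexylethyl in place of cyclohexylmethyl, would move the number beyond it.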